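Cytotoxicity notes on the anilide substituent series

This account rests on a few compounds, and the source may have more. Where it says the series, first, only, none or still open, it means among the compounds named here.

Measured so far:
Compound 1 `Cc1cc(C)cc(Cn2c(SCC(=O)Nc3ccccc3Cl)nc3ccccc32)c1` in an ADME assay on MT4 cells (Homo sapiens) for cytotoxicity (on this read-out lower numbers stand for higher toxicity in this test and higher numbers for lower toxicity in this test), gives 111000 nM.
Compound 2 `Cc1cc(C)cc(Cn2c(SCC(=O)Nc3ccccc3Br)nc3ccccc32)c1` in this assay gives only a limit, >= 143000 nM.

Compound 2 thus stands at the limit of >= 143000 nM in this assay, at which 1 of the 2 values shown sits, the top of the numbers seen. Among the measured compounds shown here, the single measured step, an at least 1.2-fold higher number from compound 1 to compound 2 (0.11 log units; that floor lies within the scatter), lies within scatter. Compound 3 `Cc1cc(C)cc(Cn2c(SCC(=O)Nc3ccccc3[N+](=O)[O-])nc3ccccc32)c1` carries nitro in place of bromo on an aromatic carbon. For the measured compounds named here, only that one step bears on it, and it shows no shift beyond scatter, so in this assay the expected step is estimated as an at least 1.1-fold lower number from compound 2 to compound 3 (0.07 log units; that floor lies within the scatter). Compound 3 is therefore estimated at 120000 nM, between 50000 nM and 250000 nM.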

Compound 3, half-maximal cytotoxic concentration: 194000 nM
Estimate against measurement, compound 3: 1.6-fold (0.21 log units) below; the measured number falls inside the stated range.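

Among the compounds shown here, on an aromatic carbon ortho to a large group, in this assay, nitro is the first replacement here to bring hydrogen-bond acceptors, and against chloro it stays within the scatter (a 1.7-fold higher number from compound 1 to compound 3 (0.24 log units; within the scatter)). So far, then, this position tolerates nitro as well as a halogen without a shift beyond scatter on this read-out. The step from bromo to nitro cannot be read, since compound 2 gives only a limit: the limit of >= 143000 nM in this assay, at which 1 of the 3 values shown sits.

Open, on these data alone, is whether an amine or a carboxylic acid at this position would shift the number beyond the scatter. Also open, as far as these compounds go, is whether the same replacements would behave alike on another carbon of the ring.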